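Moving the chain double bond one bond further out

The compounds below may be only part of what the source reports. "The series", "measured", "known", "first", "only" and "open" are said of these compounds alone.

Compound 1 `CCCCCCCCSCC1C2CCC(O2)C1C/C=C\CCCC(=O)O` gives 547000 nM in a functional assay on a cell-free system (plasma) for inhibition of thromboxane A2 receptor (Homo sapiens) (on this read-out lower numbers stand for stronger inhibition and higher numbers for weaker inhibition), the highest number of the three measured compounds. Compound 2 `CCC/C=C/CSCC1C2CCC(O2)C1C/C=C\CCCC(=O)O` gives 1300 nM in this assay, and compound 3 `CCC/C=C\CSCC1C2CCC(O2)C1C/C=C\CCCC(=O)O` gives 5700 nM. The step of a 420-fold lower number from compound 1 to compound 2 (2.62 log units; beyond the scatter) and the step of a 96-fold lower number from compound 1 to compound 3 (1.98 log units; beyond the scatter) both follow the same exchange, pent-1-en-1-yl in place of heptyl on a saturated chain carbon bound to a sulfur; the step of a 4.4-fold higher number from compound 2 to compound 3 (0.64 log units; beyond the scatter) separates the two because of the fact that one of compounds 2 and 3 is drawn with a defined configuration and the other without, at the place where they differ.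

Compound 4 `CC/C=C/CCSCC1C2CCC(O2)C1C/C=C\CCCC(=O)O` differs from compound 1 by but-1-en-1-yl in place of hexyl on a saturated chain carbon, two bonds along the chain from a sulfur, so the double bond again enters the sulfur-bearing side chain, now one bond further along it and with a shorter chain. The two measured steps from compound 1 were large and both pointed downward, so a large downward step in this assay is expected for compound 4 as well, probably somewhat short of a 420-fold lower number from compound 1 to compound 2 (2.62 log units; beyond the scatter) since the double bond sits further from the sulfur. Compound 4 is therefore estimated at 5000 nM, between 1000 nM and 30000 nM, a step of a 110-fold lower number from compound 1 to compound 4 (2.04 log units; beyond the scatter).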

Compound 4, half-maximal inhibitory concentration: 700 nM
For compound 4 the middle estimate is 7.1-fold (0.85 log units) above the measured one; measured number below the stated range.
By their numbers in this assay, from the lowest: compounds 4 and 2 (each within the scatter of the next); then compound 3; then compound 1.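

With the double bond two bonds along the chain from a sulfur, the gain over the saturated chain holds in this assay, with a 780-fold lower number from compound 1 to compound 4 (2.89 log units; beyond the scatter). The placement of the double bond makes no difference that can be read against the other compound drawn E, with a 1.9-fold lower number from compound 2 to compound 4 (0.27 log units; within the scatter). Compound 3, drawn Z, stands apart, with an 8.1-fold lower number from compound 3 to compound 4 (0.91 log units; beyond the scatter), so among these unsaturated chains only the Z compound differs beyond the scatter.

From the compounds shown here alone, whether the Z form of but-1-en-1-yl at this place would stand apart in the same way stays open, as does the effect of a triple bond or a longer unsaturated chain there. Nothing shown accounts for why compound 4 reaches the level of compound 2.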